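Exchanging an imidazolyl group for a substituted pyridinyl group

The source may hold more compounds than are shown below. What is called first, only, known or untested is meant among the compounds shown, and "the series" means these compounds.

- compound 1 `Cc1nccn1-c1cnc(NCc2c(F)ccc3c2CCO3)c2cn[nH]c(=O)c12`: 2.1
- compound 2 `Cc1ncc(-c2cnc(NCc3c(F)ccc4c3CCO4)c3cn[nH]c(=O)c23)n1C`: 1.9

Both compounds were measured in a physicochemical assay for lipophilicity, using the shake flask method, in phosphate buffer, measured as octanol-water partition, with a stated time of 30 min, at pH 7.4; on this read-out lower numbers stand for lower lipophilicity and higher numbers for higher lipophilicity. There, compound 2 stands at 1.9 and compound 1 at 2.1, two values within the usual scatter of each other.

The next compound to be measured is compound 3 `Cc1nc(CN(C)C)ccc1-c1cnc(NCc2c(F)ccc3c2CCO3)c2cn[nH]c(=O)c12`, which departs from compound 2 at one place. It carries 6-((dimethylamino)methyl)-2-methylpyridin-3-yl in place of 1,2-dimethyl-1H-imidazol-5-yl on an aromatic carbon.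

Among the measured compounds shown here, only one measured step offers any guide, and it is a number 0.20 log units lower from compound 1 to compound 2 (within the scatter). That step exchanged 2-methyl-1H-imidazol-1-yl for 1,2-dimethyl-1H-imidazol-5-yl, so it bears only loosely on the new change. For the measured compounds named here, no measured compound carries a six-membered aromatic ring at this place, or a (dimethylamino)methyl group, and the uncertainty is correspondingly wide.

No shift beyond the scatter is therefore expected in this assay, and the expected change is a number 0.20 log units higher from compound 2 to compound 3 (within the scatter). For compound 3 the estimated value is 2.1, with an expected range from 1.5 to 2.7.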

Compound 3, distribution coefficient: 2
Estimate against measurement, compound 3: 0.10 log units above; measured number inside the range.
By their numbers in this assay, from the lowest: compounds 2, 3 and 1 (each within the scatter of the next).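

In this assay, placing 6-((dimethylamino)methyl)-2-methylpyridin-3-yl on this aromatic carbon, with 11 heavy atoms entering where 7 leave, gives a number 0.10 log units higher from compound 2 to compound 3 (within the scatter), and set against the 2-methyl-1H-imidazol-1-yl group of compound 1 it gives a number 0.10 log units lower from compound 1 to compound 3 (within the scatter). Among the compounds shown here, the earlier compounds showed only two five-membered aromatic rings at this place, whereas the three compounds now span five- and six-membered rings, and all three stand within the scatter of one another on this read-out. Nothing available explains why the numbers stay so close.

The compounds shown leave open which part of the new group matters, since the six-membered ring, its methyl group and the (dimethylamino)methyl group enter together in compound 3 and no compound here carries any of them alone. They also leave open whether a carboxylic acid, a morpholine or a longer chain in place of the (dimethylamino)methyl group would keep this assay within the scatter of these three compounds, or whether such a group would move the number beyond it.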